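A Larger Ring on the Cationic Tail of Compound 2

This account rests on a few compounds, and the source may have more. Where it says the series, first, only, none or still open, it means among the compounds named here.

Three compounds that share one core and a seven-carbon chain ending in a charged nitrogen have been measured in an assay on LX2 cells for inhibition of COL1A1 promoter (Homo sapiens), read by a luciferase reporter, with a stated time of 24 h, tested at 20 uM; on this read-out lower numbers stand for a weaker effect and higher numbers for a stronger effect at the one concentration tested. In this assay compound 1 `Cc1ccc(-n2cc(C(=O)Nc3cc(F)cc(F)c3)c(=O)c3ccc(N(C)C)nc32)cc1OCCCCCCC[N+]12CCN(CC1)CC2` gives 5.07%, compound 2 `Cc1cc(-n2cc(C(=O)Nc3cc(F)cc(F)c3)c(=O)c3ccc(N(C)C)nc32)ccc1OCCCCCCC[N+]1(C)CCCC1` gives 26.1% and compound 3 `Cc1cc(OCCCCCCC[N+]2(C)CCCC2)cc(-n2cc(C(=O)Nc3cc(F)cc(F)c3)c(=O)c3ccc(N(C)C)nc32)c1` gives 4.32%. Compound 2 therefore stands highest of the three numbers, and its gap to compound 1 as well as its gap to compound 3 lies beyond the scatter, so it is the strongest of the set on this read-out.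

Compound 4 `CC[N+]1(CCCCCCCOc2ccc(-n3cc(C(=O)Nc4cc(F)cc(F)c4)c(=O)c4ccc(N(C)C)nc43)cc2C)CCCCC1` has not been measured yet. Relative to compound 2 it carries a group of 8 heavy atoms (7 carbon, 1 nitrogen; one six-membered non-aromatic ring with 1 hetero atom) in place of a group of 6 heavy atoms (5 carbon, 1 nitrogen; one five-membered non-aromatic ring with 1 hetero atom), on a saturated chain carbon, seven bonds along the chain from an oxygen on an aromatic ring. Among the measured compounds shown here, no pair of measured compounds differs in this place alone, so the size of such a step is unknown from the data. Because compound 2 gives 26.1% and the change is confined to the cationic end of the chain, the step from compound 2 to compound 4 is expected to be small, a number 5.1 percentage points lower from compound 2 to compound 4 (within the scatter), not clearly beyond the scatter in either direction. Compound 4 is accordingly estimated at 21%, with a range from 6% to 38%.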

Compound 4, a percentage reported as inhibition, at one concentration (the size of the read-out at that concentration, not a potency): 19.7%
Compound 4: middle estimate off by 1.3 percentage points, on the high side; low and high end bracket the measured number.
By their numbers in this assay, from the lowest: compounds 3 and 1 (each within the scatter of the next); then compounds 4 and 2 (each within the scatter of the next).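

The first step read at this position comes from the cationic end of the chain, on a saturated chain carbon, seven bonds along the chain from an oxygen on an aromatic ring. In this assay the exchange of the group with one five-membered non-aromatic ring for the group with one six-membered non-aromatic ring and 8 heavy atoms amounts to a number 6.4 percentage points lower from compound 2 to compound 4 (within the scatter), so for this one pair, with net charge +1 on both groups, the larger ring leaves the read-out indistinguishable from that of the parent. The data offer no measurement that would explain this outcome.

Ring size and the substituent on the charged nitrogen change together in this step, so their separate contributions cannot be told apart, and a single step cannot show how far this insensitivity extends. Going by these compounds, it remains open whether a seven-membered azepane ring, a morpholine ring, a simple trimethylammonium group or a neutral tertiary amine at the end of the chain would also stay within the scatter of compound 2 in this assay.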